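The source may report more compounds than this note shows. Statements on the series, on what has been measured and on what is new or still open speak of the compounds shown alone.

In a functional assay on NSCLC cells (Homo sapiens) for cytotoxicity, read by sulforhodamine B assay, with a stated time of 48 h (a higher number here means a weaker inhibitor of growth, a lower number a stronger inhibitor of growth), three compounds have been measured. Compound 1 `COc1ccc2c(c1)/C(=C/c1c(-c3ccncc3)nc3sccn13)C(=O)N2C` gives 550 nM. Compound 2 `COc1nc2sc(C)cn2c1/C=C1/C(=O)Nc2ccccc21` gives 5680 nM, and compound 3 `O=C1Nc2ccccc2C1=Cc1c(-c2ccncc2)nc2sccn12` gives 8970 nM. Among these three numbers compound 2 stands second highest: its nearest neighbour is compound 3, whose value lies within the scatter of its own, while compound 1 stands far lower, beyond the scatter.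

Compound 4 `COc1nc2sc(C)cn2c1/C=C1/C(=O)Nc2ccc(O)cc21` has not yet been measured in this assay. It differs from compound 2 in one place: hydroxy in place of hydrogen on an aromatic carbon. Among the measured compounds shown here, no pair of measured compounds differs by this change, so nothing in the data shows how it bears on growth inhibition. The step of a 1.1-fold lower number from compound 2 to compound 4 (0.06 log units; within the scatter) is therefore expected to lie within the scatter, in no settled direction. Compound 4 is estimated to give 5000 nM in this assay, with a range from 2000 nM to 14000 nM, until the measurement shows where it actually falls.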

Compound 4, concentration for 50% growth inhibition: 7540 nM
The estimate for compound 4 lay 1.5-fold (0.18 log units) below the measured number; the range from low to high includes it.
By their numbers in this assay, from the lowest: compound 1; then compounds 2, 4 and 3 (each within the scatter of the next).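

Hydroxy in place of hydrogen on an aromatic carbon, meta to a fused ring and para to a fused ring, gives a 1.3-fold higher number from compound 2 to compound 4 (0.12 log units; within the scatter) in this assay and so provides the first reading of this change among the compounds shown. At this place on the core of compound 2, a single hydroxy therefore leaves growth inhibition indistinguishable within the scatter, although one pair cannot show whether that holds for the change more generally. Nothing available here accounts for this result.

From the compounds shown here alone, whether a methoxy group, an amine or a carboxylic acid at this same place would also stay within the scatter remains open. Going by these compounds, it is also open whether hydroxy would behave in the same way on another carbon of this ring or on the core of compound 1.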